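The source may hold more compounds than are shown below. What is called first, only, known or untested is meant among the compounds shown, and "the series" means these compounds.

Measured so far in an ADME assay on NIH3T3 cells (Mus musculus) for inhibition, read by MTT assay, with a stated time of 48 h; a higher number here means a weaker inhibitor, a lower number a stronger inhibitor:
Compound 1 `CCc1ccc(-c2nc3ccccn3c2Sc2ccccc2)cc1`: > 100000 nM, a limit of the assay
Compound 2 `Cc1ccc(-c2nc3ccccn3c2Sc2ccccc2)cc1`: > 100000 nM, a limit of the assay
Compound 3 `COc1ccc(-c2nc3ccccn3c2Sc2ccccc2)cc1`: 91700 nM

Among these three, only compound 3 has a reading that is an actual number, 91700 nM. The other two results stand at the limit of > 100000 nM in this assay, at which 2 of the 3 values shown sit.

The next compound, compound 4 `CSc1ccc(-c2nc3ccccn3c2Sc2ccccc2)cc1`, keeps the shared core and has methylsulfanyl in place of methoxy on an aromatic carbon, para to a large group: methylsulfanyl in place of methoxy on an aromatic carbon. Going by the values given here, no measured step makes this exact change, but three involve the same aromatic carbon. They are an at least 1.0-fold lower number from compound 1 to compound 3 (0.03 log units; that floor lies within the scatter), an at least 1.0-fold lower number from compound 2 to compound 3 (0.03 log units; that floor lies within the scatter) and a step that the two limits leave unreadable from compound 1 to compound 2. The first two give only floors, and the third cannot be read at all, so none of them shows a change of measurable size at this place.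

With so little evidence of change at this carbon in this assay, no step beyond the scatter is expected, in either direction. The expected change is a 1.0-fold higher number from compound 3 to compound 4 (0.02 log units; within the scatter). The estimate for compound 4 is 95000 nM, with an expected range from 50000 nM to 160000 nM. A report of a limit rather than a number is also quite possible.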

Compound 4, half-maximal inhibitory concentration: > 100000 nM
Compound 4 gave a limit, no number (the forecaster's own chance of this, stated with the estimate: 50%); middle value at least 1.0-fold (0.02 log units) away from the limit.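

In this assay, going by these compounds alone, methylsulfanyl in place of methoxy on the aromatic carbon gives an at least 1.0-fold higher number from compound 3 to compound 4 (0.03 log units; that floor lies within the scatter), so this exact change, now seen directly, still shows no step of measurable size. The steps from compound 1 and compound 2 to compound 4 cannot be read, and compound 3 remains the only compound shown with an actual number. The series therefore gives no ranking of the groups at this carbon because its readings rest mostly on one limit: the limit of > 100000 nM in this assay, at which 3 of the 4 values shown sit.

The compounds shown leave open whether another group at this carbon, such as an amine or a carboxylic acid, would give a number clearly apart from this limit in this assay. They also leave open whether a change elsewhere on the shared core would move the reading at all.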